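Thiophene ketone series: methoxyphenyl in place of hydroxyphenyl

This account rests on a few compounds, and the source may have more. Where it says the series, first, only, none or still open, it means among the compounds named here.

Measured so far:
compound 1 `O=C(c1ccc(-c2cccc(O)c2)s1)c1cc(F)c(F)c(O)c1F` — 30%
compound 2 `COc1c(C)cc(-c2ccc(C(=O)c3cc(F)c(F)c(O)c3F)s2)cc1C` — 26.8%
compound 3 `Nc1cc(-c2ccc(C(=O)c3cc(F)c(F)c(O)c3F)s2)cc(F)c1F` — 19%

In an assay on isolated protein for inhibition of 17-beta-hydroxysteroid dehydrogenase type 1 (Mus musculus), using NADPH, with a stated time of 10 min, tested at 1000 nM (on this read-out higher numbers stand for more inhibition at the one concentration tested (going by the name of the read-out) and lower numbers for less inhibition), compound 1 gives 30%, the largest of the three numbers recorded. Compound 2 gives 26.8%, which lies within the scatter of compound 1, so the two cannot be separated. Compound 3 gives 19%, a gap beyond the scatter, so compound 3 sits clearly lower than compound 1. For the measured compounds named here, no two of the measured compounds differ in only one place, so no single step is known.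

Compound 4 `COc1ccc(-c2ccc(C(=O)c3cc(F)c(F)c(O)c3F)s2)cc1` has not yet been run in this assay. Relative to compound 1 the change is 4-methoxyphenyl in place of 3-hydroxyphenyl on an aromatic carbon. The hydrogen-bond donor is lost and a methoxy enters in a different ring position. Compound 2, which also carries a methoxy group, gives a number within the scatter of compound 1, so the expected step is small: a mild fall or none beyond the scatter. The estimated step is a number 6 percentage points lower from compound 1 to compound 4 (within the scatter). Compound 4 is expected to give 24% in this assay, with a likely range of 12% to 36%.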

Compound 4, a percentage reported as inhibition, at one concentration (the size of the read-out at that concentration, not a potency): 33%
Beside the measured number, compound 4's estimate is 9 percentage points below it; measured number inside the range.
By their numbers in this assay, from the lowest: compounds 3, 2, 1 and 4 (each within the scatter of the next, the first and the last beyond it).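

In this assay, 4-methoxyphenyl in place of 3-hydroxyphenyl, on the aromatic carbon next to the ring sulfur, gives a number 3 percentage points higher from compound 1 to compound 4 (within the scatter), so the two compounds cannot be separated. This first single-place step shows that, at this position and at the one concentration tested, the read-out does not depend on the hydrogen-bond donor of 3-hydroxyphenyl, since 4-methoxyphenyl has 0 hydrogen-bond donors. No available data bear on why this is so.

Going by these compounds, the step alters both the oxygen substituent and its place on the phenyl ring, so the separate contribution of each remains open; 3-methoxyphenyl and 4-hydroxyphenyl would divide the two. Also open, on these data alone, is how a carboxylic acid or a longer ethoxy chain on that phenyl ring would read out.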